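The compounds below may be only part of what the source reports. "The series", "measured", "known", "first", "only" and "open" are said of these compounds alone.

Measured so far:
compound 1 `CSc1ncnc2c1nnn2[C@@H]1O[C@H](COC(C)=O)[C@@H](OC(C)=O)[C@H]1OC(C)=O` gives 0.5 uM
compound 2 `CCSc1ncnc2c1nnn2[C@@H]1O[C@H](CO)[C@@H](O)[C@H]1O` gives 0.1 uM

In a functional assay on HEp-2 cells (Homo sapiens) for inhibition (a lower number here means that less compound is needed, a higher number that more compound is needed for the effect), compound 2 stands at the lowest number of the two, and compound 1 comes out at the higher number. Compound 3 `CCCCNc1ncnc2c1nnn2[C@@H]1O[C@H](CO)[C@@H](O)[C@H]1O` is not yet measured. It differs from compound 2 in one place (butylamino in place of ethylsulfanyl on an aromatic carbon). Going by the values given here, no measured pair shows this kind of change, so the size of the step is uncertain. Compound 3 is expected to remain fairly close to compound 2, with an expected step of a 3.0-fold higher number from compound 2 to compound 3 (0.48 log units; beyond the scatter) toward a somewhat higher number, possibly within scatter. For compound 3 the estimate is 0.3 uM with a range from 0.05 uM to 2 uM.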

Compound 3, concentration for half-maximal effect: 0.3 uM
Compound 3: the middle estimate sits on the measured number at the digits printed; the measured number falls inside the stated range.
By their numbers in this assay, from the lowest: compound 2; then compounds 3 and 1 (each within the scatter of the next).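

In this assay, butylamino in place of ethylsulfanyl on this aromatic carbon gives a 3.0-fold higher number from compound 2 to compound 3 (0.48 log units; beyond the scatter), a modest step, so the position still gives a low number with a nitrogen-linked chain in place of a sulfur-linked one. The linking atom and the chain length change together, so this pair cannot separate their contributions. Nothing measured here explains the step.

Still open, on these data alone, is how ethylamino or butylsulfanyl would compare, since either would separate the two changes. Also open, as far as these compounds go, is how a cyclic amine such as morpholine would behave at this position.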